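Series notes: amide variation and a hydrazone change

The compounds below may be only part of what the source reports. "The series", "measured", "known", "first", "only" and "open" are said of these compounds alone.

Measured so far in an ADME assay on HT-29 cells (Homo sapiens) for inhibition, read by MTT assay, with a stated time of 72 h; on this read-out higher numbers stand for weaker inhibition and lower numbers for stronger inhibition:
- compound 1 `Nc1cccc(Nc2nc(N/N=C/c3ccc(F)cc3)ncc2Cl)c1`: compound 1 gives 12300 nM
- compound 2 `C=CC(=O)Nc1cccc(Nc2nc(N/N=C/c3ccc(F)cc3)ncc2Cl)c1`: compound 2 gives 6340 nM
- compound 3 `CN(C)C/C=C/C(=O)Nc1cccc(Nc2nc(N/N=C/c3ccc(F)cc3)ncc2Cl)c1`: compound 3 gives 3300 nM

Compound 3 has the lowest number of the three. The step of a 3.7-fold lower number from compound 1 to compound 3 (0.57 log units; beyond the scatter) lies beyond the scatter, whereas a 1.9-fold lower number from compound 2 to compound 3 (0.28 log units; within the scatter) and a 1.9-fold lower number from compound 1 to compound 2 (0.29 log units; within the scatter) each lie within it, so compound 3 is separated from compound 1 but not from compound 2.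

Compound 4 `C/C(=N\Nc1ncc(Cl)c(Nc2cccc(NC(=O)/C=C/CN(C)C)c2)n1)c1ccc(F)cc1F` has not been measured. It differs from compound 3 in a group of 11 heavy atoms (8 carbon, 1 nitrogen, 2 fluorine; one six-membered aromatic ring of carbon only) in place of a group of 9 heavy atoms (7 carbon, 1 nitrogen, 1 fluorine; one six-membered aromatic ring of carbon only), on a nitrogen on an aromatic ring. All three measured steps concern the group on the other aromatic nitrogen of the shared core, the one carrying the acrylamide; none of them touches the part that changes from compound 3 to compound 4. For the measured compounds named here, there is therefore no measured step in this assay that bears directly on the change, and the expectation rests on the value of compound 3 alone.

Going by the values given here, with no comparable step available, the expected step of no change at the digits printed from compound 3 to compound 4 (within the scatter) is taken as none beyond the scatter, with a wide range in either direction. Compound 4 is thus estimated at 3300 nM, with a range from 1000 nM to 11000 nM.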

Compound 4, half-maximal inhibitory concentration: 3460 nM
Estimate against measurement, compound 4: 1.0-fold (0.02 log units) below; measured number inside the range.
By their numbers in this assay, from the lowest: compounds 3, 4, 2 and 1 (each within the scatter of the next, the first and the last beyond it).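

For the compounds shown here, this is the first step in this assay at this place, on a nitrogen on an aromatic ring, and it reads a 1.0-fold higher number from compound 3 to compound 4 (0.02 log units; within the scatter). With the group of 11 heavy atoms (8 carbon, 1 nitrogen, 2 fluorine) in place of the group of 9 heavy atoms (7 carbon, 1 nitrogen, 1 fluorine), one more carbon and one more fluorine leave the read-out without a separable change on the background of compound 3, something the earlier amide steps could not show, as that group stays the same across all of them. No supporting measurement bears on why the two numbers agree.

On these data alone, it remains open whether the same exchange would read alike with the vinylcarbonyl amide of compound 2 or the free aromatic amine of compound 1, as the step is known only on the background of compound 3. Also open, as far as these compounds go, is how this place responds to a larger departure, such as a morpholine, a carboxylic acid or a longer alkyl chain in place of the aromatic ring of carbon only.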